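This account rests on a few compounds, and the source may have more. Where it says the series, first, only, none or still open, it means among the compounds named here.

Measured so far:
compound 1, `COc1ccc(C2=NN(C(=O)c3ccc(Cl)nc3)C(c3ccc(OCc4ccccc4)cc3)C2)cc1`: 10600 nM
compound 2, `COc1ccc(C2=NN(C(=O)c3ccc(C)nc3Cl)C(c3ccc(OCc4ccccc4)cc3)C2)cc1`: 10500 nM
compound 3, `O=C(c1ccc(Cl)nc1)N1N=C(c2ccc(Cl)cc2)CC1c1ccc(Br)cc1`: 9870 nM

These three compounds were tested in a functional assay on WM 266-4 cells (Homo sapiens) for antiproliferative activity, read by MTT assay, with a stated time of 24 h (on this read-out higher numbers stand for weaker inhibition of growth and lower numbers for stronger inhibition of growth), where compound 1 gives 10600 nM. Compound 2 carries one change against compound 1, namely (2-chloro-6-methylpyridin-3-yl in place of 6-chloropyridin-3-yl on a carbonyl carbon), and in this assay compound 2 gives 10500 nM; the step is a 1.0-fold lower number from compound 1 to compound 2 (0.00 log units; within the scatter). Compound 3 is built on a different core, and how the two cores differ is not broken down here; in this assay compound 3 gives 9870 nM.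

Compound 4, `Cc1ccc(C(=O)N2N=C(c3ccc(Cl)cc3)CC2c2ccc(Br)cc2)c(Cl)n1`, has not yet been tested. It differs from compound 3 by 2-chloro-6-methylpyridin-3-yl in place of 6-chloropyridin-3-yl on a carbonyl carbon, the same change that was made from compound 1 to compound 2, at the same kind of place. Since that earlier step was a 1.0-fold lower number from compound 1 to compound 2 (0.00 log units; within the scatter), the step from compound 3 to compound 4 is expected to be a 1.0-fold lower number from compound 3 to compound 4 (0.02 log units; within the scatter). On this basis compound 4 is estimated at 9500 nM in this assay, with the expected range running from 4500 nM to 20000 nM.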

Compound 4, concentration for 50% growth inhibition: 10800 nM
Beside the measured number, compound 4's estimate is 1.1-fold (0.06 log units) below it, and the stated range covers the measured number.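

On the core of compound 3, putting 2-chloro-6-methylpyridin-3-yl in place of 6-chloropyridin-3-yl on the carbonyl carbon gives, in this assay, a 1.1-fold higher number from compound 3 to compound 4 (0.04 log units; within the scatter). Set beside the same change on the core of compound 1, the two steps agree: the same change on two cores in this assay, a 1.0-fold lower number (0.00 log units; within the scatter) from compound 1 to compound 2 and a 1.1-fold higher number (0.04 log units; within the scatter) from compound 3 to compound 4, 1.1-fold (0.04 log units) apart, within the scatter of two such steps Both steps lie within the scatter, so the agreement shows only that this change leaves no readable mark on either of these two cores; it does not show that a step of clear size would carry from one core to another, or that other cores would behave the same way.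

The compounds shown leave open whether a different group on the carbonyl carbon, such as a pyridine ring carrying an amine or a carboxylic acid, would move the number in this assay on either core. They also leave open whether any such group would give a step beyond the scatter that could then be tested on both cores.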